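The compounds below may be only part of what the source reports. "The series", "measured", "known", "first", "only" and "open" are said of these compounds alone.

Compound 1 `O=C(Nc1ccc(-n2ncc3c(C(F)(F)F)cccc32)cc1)Nc1ccc(Cl)c(C(F)(F)F)c1` gives 3000 nM in a functional assay on A549 cells (Homo sapiens) for cytotoxicity, read by MTT assay, with a stated time of 72 h; on this read-out higher numbers stand for weaker inhibition and lower numbers for stronger inhibition. Compound 2 `O=C(Nc1ccc(-n2ncc3c(Br)cccc32)cc1)Nc1ccc(Cl)c(C(F)(F)F)c1` gives 2300 nM. Compound 3 `Cc1cccc2c1cnn2-c1ccc(NC(=O)Nc2ccc(Cl)c(C(F)(F)F)c2)cc1` gives 5500 nM.

Among the compounds with values here, compound 1 stands second highest of the three numbers: compound 2 lies close to it a 1.3-fold lower number from compound 1 to compound 2 (0.12 log units; within the scatter) and compound 3 somewhat further a 1.8-fold higher number from compound 1 to compound 3 (0.26 log units; within the scatter), while the only step beyond the scatter is a 2.4-fold higher number from compound 2 to compound 3 (0.38 log units; beyond the scatter). Compound 4 `O=C(Nc1ccc(-n2ncc3c(C(F)(F)F)cccc32)cc1)Nc1ccc(C(F)(F)F)cc1` differs from compound 1 by 4-(trifluoromethyl)phenyl in place of 4-chloro-3-(trifluoromethyl)phenyl on an amide-type nitrogen. Within the data shown here, none of the measured steps touches this part of the molecule; all three change a group on the shared core, so no step bears directly on the change. Compound 4 is therefore expected to stay close to compound 1, with a weak step a 1.7-fold higher number from compound 1 to compound 4 (0.22 log units; within the scatter) toward a higher number. The estimate for compound 4 is 5000 nM, within 1500 nM to 16000 nM.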

Compound 4, half-maximal inhibitory concentration: 800 nM
Compound 4: middle estimate off by 6.3-fold (0.80 log units), on the high side; the measured number lies below the stated range.
By their numbers in this assay, from the lowest: compound 4; then compounds 2, 1 and 3 (each within the scatter of the next, the first and the last beyond it).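

The aryl group on the amide-type nitrogen turns out to be a sensitive place: 4-(trifluoromethyl)phenyl in place of 4-chloro-3-(trifluoromethyl)phenyl gives a 3.8-fold lower number from compound 1 to compound 4 (0.57 log units; beyond the scatter), a larger step toward stronger inhibition than any printed among the changes on the shared core. A simpler aryl group is thus compatible with cytotoxicity here. Nothing available explains this shift. As far as these compounds go, whether the same change would also lower the numbers with the bromo and methyl cores of compound 2 and compound 3 stays open. So does the outcome with a 4-aminophenyl or 4-methoxyphenyl group on that nitrogen.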